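The source may report more compounds than this note shows. Statements on the series, on what has been measured and on what is new or still open speak of the compounds shown alone.

Compound 1 `COc1ccc2c(c1)OC(c1cc(OC)c(OC)c(OC)c1)C(C(=O)OCCc1ccccc1)=C2` — 16200 nM
Compound 2 `COc1ccc2c(c1)OC(c1cc(OC)c(OC)c(OC)c1)C(C(N)=O)=C2` — > 50000 nM

In a functional assay for inhibition of nuclear factor NF-kappa-B complex (Homo sapiens) (a higher number here means a weaker inhibitor, a lower number a stronger inhibitor), compound 1 gives 16200 nM. Compound 2 yields only a limit of the assay, > 50000 nM, sitting at the limit of > 50000 nM in this assay, at which 1 of the 2 values shown sits. For the measured compounds named here, the one measured step, an at least 3.0-fold higher number from compound 1 to compound 2 (0.48 log units; beyond the scatter), shows the group on that carbonyl carbon matters. Compound 3 `COc1ccc2c(c1)OC(c1cc(OC)c(OC)c(OC)c1)C(C(C)=O)=C2` differs by methyl in place of amino on a carbonyl carbon. Going by the values given here, no measured step tests this exact exchange; the step from compound 1 to compound 2 suggests a modest shift is possible. Compound 3 is expected near 30000 nM, between 9000 nM and 50000 nM. The expected step is an at least 1.6-fold lower number from compound 2 to compound 3 (0.22 log units; that floor lies within the scatter).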

Compound 3, half-maximal inhibitory concentration: 14100 nM
Beside the measured number, compound 3's estimate is 2.1-fold (0.33 log units) above it, and the stated range covers the measured number.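

Methyl in place of amino on the carbonyl carbon gives an at least 3.5-fold lower number from compound 2 to compound 3 (0.54 log units; beyond the scatter), so the drop in inhibition seen with compound 2 does not extend to every small group here. Methyl in place of phenethyloxy gives a 1.1-fold lower number from compound 1 to compound 3 (0.06 log units; within the scatter), so the phenethyloxy group is not needed for this level of inhibition. The value of compound 2 is a limit, so the first step has only a floor: the limit of > 50000 nM in this assay, at which 1 of the 3 values shown sits.

The compounds shown leave open how a carboxylic acid, a methylamino group or an ethyl chain on this carbonyl carbon would compare.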